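Removing a Methoxy Group: Expected Effect on Paw Swelling

A few compounds are considered here, and "the series" means these few. Any claim that something is new, unique, unknown or untested is made for them only; others in the source may bear on it.

Compound 2 `COc1ccc(N2C(=O)CSC2c2sc(Cc3ccc(Cl)cc3)nc2C)cc1` gives 28.6% in a functional assay on the whole organism (strain Wistar albino) for inhibition, with Rattus norvegicus as the target, read by paw edema, with stated times of 1 h and 2 h, at a dose of 40 mg/kg by the oral route (on this read-out higher numbers stand for more inhibition at the one dose given (going by the name of the read-out) and lower numbers for less inhibition), the lower of the two measured numbers. Compound 1 `Cc1nc(Cc2ccc(Cl)cc2)sc1C1SCC(=O)N1c1ccc(F)c(Cl)c1` gives 45.1% in this assay. Going by the values given here, the one measured step, a number 16.5 percentage points lower from compound 1 to compound 2 (beyond the scatter), swaps the whole group on the amide-type nitrogen in a ring. Compound 3 `Cc1nc(Cc2ccc(Cl)cc2)sc1C1SCC(=O)N1c1ccccc1` differs from compound 2 by hydrogen in place of methoxy on an aromatic carbon. Among the compounds with values here, no measured step removes a methoxy group, so only the modest size of that earlier change offers guidance, and it gives no direction. The expected step is a number 4.4 percentage points higher from compound 2 to compound 3 (within the scatter). Compound 3 is expected to give 33%, between 18% and 50%.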

Compound 3, a percentage reported as inhibition, in the whole organism at one dose (the size of the read-out at that dose, not a potency): "not active" (no number reported)
No number was reported for compound 3; there is nothing to compare the estimate with.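

Going by these compounds alone, compound 3 is reported only as "not active", with no number, so no step from compound 2 to compound 3 can be read. No data at hand explain this result. From the compounds shown here alone, how much the methoxy group itself counts in this assay stays open.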